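From a Sulfanyl Pyridine to an Anilino Side Chain

The source may report more compounds than this note shows. Statements on the series, on what has been measured and on what is new or still open speak of the compounds shown alone.

For the measured compounds named here, in a functional assay on the whole organism with Mus musculus as the target (a higher number here means that more compound is needed for the effect, a lower number that less compound is needed), compound 1 (`Cc1c(C)c2c(c(C)c1N)CC(C)(CSc1ccncc1)O2`) gives 19.9 mg/kg as the only actual number so far. Compound 2 (`Cc1c(C)c2c(c(C)c1N)CC(C)(CN1CCN(C(c3ccccc3)c3ccccc3)CC1)O2`) shows > 50 mg/kg as a limit of the assay and not a number. Compound 3 (`Cc1c(C)c2c(c(C)c1N)CC(C)(CNc1ccccc1)O2`) keeps the core of compound 1 and carries anilino in place of (pyridin-4-yl)sulfanyl on a saturated chain carbon bound to a saturated ring carbon. Going by the values given here, no measured step bears on this change, so the expected step of a 1.0-fold higher number from compound 1 to compound 3 (0.00 log units; within the scatter) in this assay stays within the scatter, with no direction favoured. For compound 3 the estimated dose is 20 mg/kg within an expected range of 7 mg/kg to 50 mg/kg for now.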

Compound 3, dose for 50% inhibition: 15.7 mg/kg
Compound 3: middle estimate off by 1.3-fold (0.11 log units), on the high side, and the stated range covers the measured number.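

Anilino in place of (pyridin-4-yl)sulfanyl on a saturated chain carbon bound to a saturated ring carbon gives a 1.3-fold lower number from compound 1 to compound 3 (0.10 log units; within the scatter) in this assay, so the two groups cannot be told apart at this position. The pyridine nitrogen and the sulfur of the group that leaves are thus not required for a dose of this order in this pair. Nothing at hand explains this result. Going by these compounds, it remains open whether a chlorine or methoxy on the anilino ring, or a longer chain before that ring, would move the dose beyond the scatter.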